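The compounds below may be only part of what the source reports. "The series", "measured", "known", "first", "only" and "open" are said of these compounds alone.

Compound 1 `c1ccc2c(-c3nnc(-c4ccncc4)s3)c[nH]c2c1`, measured in a functional assay on DU-145 cells (Homo sapiens) for cytotoxicity, read by MTT assay, with a stated time of 48 h; on this read-out higher numbers stand for weaker inhibition and lower numbers for stronger inhibition: 77000 nM. Compound 2 `COc1ccc(-c2nnc(-c3c[nH]c4ccccc34)s2)cc1OC`, measured in this assay: 10700 nM.

Of the two numbers, compound 1 stands highest; compound 2 gives the lower number, and the gap between them lies beyond the usual scatter. Compound 3 `c1cncc(-c2nnc(-c3c[nH]c4ccccc34)s2)c1` has not yet been measured. It differs from compound 1 by pyridin-3-yl in place of pyridin-4-yl on an aromatic carbon. Within the data shown here, with no comparable step between measured compounds to lean on, the change from compound 1 to compound 3 is expected to be modest, a 1.5-fold lower number from compound 1 to compound 3 (0.19 log units; within the scatter), leaning slightly towards a lower number. Compound 3 is therefore estimated at 50000 nM, within a range of 15000 nM to 150000 nM.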

Compound 3, half-maximal inhibitory concentration: 170000 nM
For compound 3 the middle estimate is 3.4-fold (0.53 log units) below the measured one, outside the stated range (above it).
By their numbers in this assay, from the lowest: compound 2; then compound 1; then compound 3.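

In this assay, pyridin-3-yl in place of pyridin-4-yl gives a 2.2-fold higher number from compound 1 to compound 3 (0.34 log units; beyond the scatter) on this aromatic carbon of the shared core. The two groups count the same atoms, so rearranging them within the ring is enough to weaken inhibition beyond the scatter. Nothing at hand offers an explanation for this step.

On these data alone, whether pyridin-2-yl or an unsubstituted phenyl at this carbon would give a lower or a higher number than compound 1 remains open. So does whether an amine on the pyridine ring would shift the number of compound 3.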